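The compounds below may be only part of what the source reports. "The series", "measured", "known", "first", "only" and "open" are said of these compounds alone.

Measured compounds:
- compound 1, `COc1ccccc1-c1cn(-c2ccc(O)c(C(=O)Nc3cccc(C(F)(F)F)c3)c2)nn1`, 65%
- compound 2, `COc1ccc(-c2cn(-c3ccc(O)c(C(=O)Nc4cccc(C(F)(F)F)c4)c3)nn2)cc1`, 12%
- compound 3, `COc1cc(OC)cc(-c2cn(-c3ccc(O)c(C(=O)Nc4cccc(C(F)(F)F)c4)c3)nn2)c1`, 73%

All three share one core and differ only in the methoxy-bearing ring attached to an aromatic carbon. In a functional assay on CCRF-CEM cells (Homo sapiens) for inhibition, read by MTT assay, with a stated time of 2 days, tested at 10 uM (on this read-out higher numbers stand for more inhibition at the one concentration tested (going by the name of the read-out) and lower numbers for less inhibition), compound 2 gives 12%, the lowest of the three numbers: a number 61 percentage points higher from compound 2 to compound 3 (beyond the scatter), and the move from compound 2 back to compound 1 is equally clear in size, while a number 8 percentage points higher from compound 1 to compound 3 (within the scatter).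

Compound 4, `COc1ccc(-c2cn(-c3ccc(O)c(C(=O)O)c3)nn2)cc1`, leaves the methoxy-bearing ring of compound 2 untouched and instead changes the other end of the core: hydroxy in place of (3-(trifluoromethyl)phenyl)amino on a carbonyl carbon. Going by the values given here, none of the measured steps touches this position; all three concern the methoxy-bearing ring alone, so they give no guide to the size or direction of this change. What the measured numbers do give is a low starting point for compound 2, below which little room remains. On that basis compound 4 is expected to show a number 2 percentage points lower from compound 2 to compound 4 (within the scatter), that is, nothing beyond the scatter. The estimate for compound 4 in this assay is 10%, within the range 0% to 30%.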

Compound 4, a percentage reported as inhibition, at one concentration (the size of the read-out at that concentration, not a potency): 9%
For compound 4 the middle estimate is 1 percentage points above the measured one; low and high end bracket the measured number.
By their numbers in this assay, from the lowest: compounds 4 and 2 (each within the scatter of the next); then compounds 1 and 3 (each within the scatter of the next).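

In this assay the change on the carbonyl carbon gives a number 3 percentage points lower from compound 2 to compound 4 (within the scatter), so with the 4-methoxyphenyl ring in place, compounds carrying hydroxy and (3-(trifluoromethyl)phenyl)amino at this position cannot be told apart. Both numbers are low, so this pair cannot show whether the (3-(trifluoromethyl)phenyl)amino group matters in compounds that score well. Nothing measured on these compounds offers an explanation for this result.

Still open, on these data alone, is what hydroxy in place of (3-(trifluoromethyl)phenyl)amino would do with the methoxy-bearing rings of compound 1 and compound 3, whose numbers leave far more room to fall. Also open, as far as these compounds go, is how a simple amine such as methylamino, or a benzylamino group, would behave on the same carbonyl carbon.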